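The source may hold more compounds than are shown below. What is called first, only, known or untested is meant among the compounds shown, and "the series" means these compounds.

Measured so far:
compound 1 `COc1ccc(-c2[nH]c3ccccc3c2/C=C(\C#N)S(=O)(=O)c2ccccc2)cc1` with 1300 nM
compound 2 `COc1ccc2[nH]c(-c3ccccc3)c(/C=C(\C#N)S(=O)(=O)c3ccccc3)c2c1` with 7400 nM

In a functional assay on LOX IMVI cells (Homo sapiens) for inhibition, read by sulforhodamine B assay, with a stated time of 48 h (a higher number here means a weaker inhibitor of growth, a lower number a stronger inhibitor of growth), compound 2 gives 7400 nM, the highest of the two numbers; compound 1 gives 1300 nM, a gap beyond the scatter. Compound 3 `N#C/C(=C\c1c(-c2ccccc2)[nH]c2ccccc12)S(=O)(=O)c1ccccc1` differs from compound 2 by one change: hydrogen in place of methoxy on an aromatic carbon, the methoxy leaving the six-membered ring of the fused two-ring system. Going by the values given here, no measured pair shows this exact change, so the expected step is uncertain; a modest move toward a lower number, or none beyond the scatter, seems plausible. Compound 3 is estimated at 3500 nM, within a range of 1200 nM to 10000 nM, an expected step of a 2.1-fold lower number from compound 2 to compound 3 (0.33 log units; beyond the scatter).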

Compound 3, concentration for 50% growth inhibition: 4600 nM
The estimate for compound 3 lay 1.3-fold (0.12 log units) below the measured number; the range from low to high includes it.
By their numbers in this assay, from the lowest: compound 1; then compounds 3 and 2 (each within the scatter of the next).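

In this assay, hydrogen in place of methoxy on the six-membered ring of the fused system gives a 1.6-fold lower number from compound 2 to compound 3 (0.21 log units; within the scatter), so the methoxy shows no clear effect at this position. The same swap at the methoxy of compound 1, which sits elsewhere on the molecule, gives a 3.5-fold higher number from compound 1 to compound 3 (0.55 log units; beyond the scatter), so the effect of this change depends on where it is made. Nothing measured yet explains that contrast. On these data alone, whether an amine or a chlorine atom on the fused ring would also match hydrogen remains open.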